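This account rests on a few compounds, and the source may have more. Where it says the series, first, only, none or still open, it means among the compounds named here.

Among the measured compounds shown here, compound 1 `COc1cc2c(Oc3ccc(NC(=O)c4nn(-c5cccc(F)c5)c(=O)cc4C)cc3F)ccnc2cc1OCCCN1CCC(C)CC1` is one of two compounds measured in a functional assay on U-87MG ATCC cells (Homo sapiens) for inhibition, read by MTT assay, with a stated time of 72 h; on this read-out higher numbers stand for weaker inhibition and lower numbers for stronger inhibition. In this assay compound 1 gives 1800 nM, the highest of the two numbers. Compound 2 `COc1cc2c(Oc3ccc(NC(=O)c4nn(-c5cccc(F)c5)c(=O)cc4C)cc3F)ccnc2cc1OCCCN1CCN(C)CC1` differs from it only at the end of the chain, and in this assay compound 2 gives 1590 nM; the step of a 1.1-fold lower number from compound 1 to compound 2 (0.05 log units; within the scatter) lies within the scatter. Compound 3 `COc1cc2c(Oc3ccc(NC(=O)c4nn(-c5ccc(Cl)cc5)c(=O)cc4C)cc3F)ccnc2cc1OCCCN1CCC(C)CC1` has not been measured. It differs from compound 1 by 4-chlorophenyl in place of 3-fluorophenyl on an aromatic nitrogen, a change on the aromatic nitrogen of the shared core. For the measured compounds named here, no measured step touches that part of the molecule: the only step at hand, a 1.1-fold lower number from compound 1 to compound 2 (0.05 log units; within the scatter), concerns the amine on the chain and is itself within the scatter. Nothing in the data therefore points to a step in this assay beyond the scatter in either direction. Compound 3 is expected to give about 1800 nM in this assay, with a range from 600 nM to 5400 nM, an expected step of no change at the digits printed from compound 1 to compound 3 (within the scatter).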

Compound 3, half-maximal inhibitory concentration: 1350 nM
Compound 3: middle estimate off by 1.3-fold (0.12 log units), on the high side; measured number inside the range.
By their numbers in this assay, from the lowest: compounds 3, 2 and 1 (each within the scatter of the next).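

Among the compounds shown here, the step of a 1.3-fold lower number from compound 1 to compound 3 (0.12 log units; within the scatter) is the first measured on the aromatic nitrogen of the shared core in this assay, and it lies within the scatter. Both the halogen and its place on the phenyl ring differ between 3-fluorophenyl and 4-chlorophenyl, yet this double difference does not separate the two groups on this read-out, so this substituent on the aromatic nitrogen, like the amine on the chain, has so far shown no step beyond the scatter. Nothing measured here offers an explanation for the size of this step.

The compounds shown leave open how 3-chlorophenyl or 4-fluorophenyl would read, which would separate the halogen from its place on the ring. They also leave open whether an unsubstituted phenyl, a pyridyl ring or a small alkyl group on that nitrogen would move the number beyond the scatter.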